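The source may report more compounds than this note shows. Statements on the series, on what has been measured and on what is new or still open speak of the compounds shown alone.

Of the compounds shown here, two have been measured so far in an ADME assay on microsomes from liver (Homo sapiens) for metabolic stability; a higher number here means that the compound lasts longer, a lower number that the compound disappears faster. Compound 1 (`C[C@H](CSc1nonc1/C(=N/O)Nc1ccc(F)c(Br)c1)NC(=O)CS(N)(=O)=O`) gives 0.77 h, and compound 2 (`O=C(NCCSc1nonc1/C(=N/O)Nc1ccc(F)c(C(F)F)c1)C1CS(=O)(=O)C1`) gives 1.28 h. These two values lie within the scatter of each other, so compound 2 stands level with compound 1 on the numbers available.

Compound 3 (`CS(=O)(=O)CC(=O)NCCSc1nonc1/C(=N/O)Nc1ccc(F)c(C(F)F)c1`) departs from compound 2 in one place, on a carbonyl carbon whose other neighbour is an amide-type nitrogen: a group of 5 heavy atoms (2 carbon, 2 oxygen, 1 sulfur; no ring) in place of a group of 6 heavy atoms (3 carbon, 2 oxygen, 1 sulfur; one four-membered non-aromatic ring with 1 hetero atom), on a carbonyl carbon. The four-membered non-aromatic ring of compound 2 is gone, and the entering (methylsulfonyl)methyl group has no ring. The rest of the structure stays the same.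

Going by the values given here, no measured pair shows a change of this kind, so the data give no size or direction for this step. With nothing to point either way, the expectation is for no step beyond the scatter, and the value of compound 2 is the best starting point. The expected change is small, a 1.2-fold lower number from compound 2 to compound 3 (0.07 log units; within the scatter). For compound 3 the estimated half-life is 1.1 h, with an expected range from 0.55 h to 2.2 h.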

Compound 3, half-life: 1.27 h
Beside the measured number, compound 3's estimate is 1.2-fold (0.06 log units) below it, and the stated range covers the measured number.
By their numbers in this assay, from the lowest: compounds 1, 3 and 2 (each within the scatter of the next).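

Going by these compounds alone, this is the first step that can be read in this assay, and it concerns the place on a carbonyl carbon whose other neighbour is an amide-type nitrogen. Opening out the group with the four-membered non-aromatic ring to the (methylsulfonyl)methyl group gives a 1.0-fold lower number from compound 2 to compound 3 (0.00 log units; within the scatter), so for this pair the two compounds read alike and the ring is not required for a half-life at this level. No measurement shown here offers an explanation for this result.

As far as these compounds go, because the two groups that have been compared at this place both contain sulfur and oxygen, it remains open whether a group without them, such as an amine or a carboxylic acid, or a longer chain carrying the sulfonyl group, would also read alike in this assay. This is also a single pair on a single version of the rest of the structure, so it cannot yet say whether the same exchange would read the same way if another part of the molecule were different.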